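N-Demethylation of the Ring Amine: Cytotoxicity Outlook

The source may report more compounds than this note shows. Statements on the series, on what has been measured and on what is new or still open speak of the compounds shown alone.

Compound 1 `Cc1nc(C(NC(=O)C(=O)Nc2ccc(Cl)cc2)C2CCCCN2C)sc1CCO` belongs to a small set of oxamides built on a shared core with a saturated nitrogen ring and a hydroxy-bearing chain. In an ADME assay on TZM-b1 cells (Homo sapiens) for cytotoxicity, read by XTT assay, with a stated time of 3 days (a lower number here means that less compound is tolerated, a higher number that more compound is tolerated), compound 1 gives 36000 nM. Compound 2 `Cc1nc(C(NC(=O)C(=O)Nc2ccc(Cl)cc2)C2CCCN2)sc1CO` differs from compound 1 in ring size and in the length of the hydroxy-bearing chain. In this assay compound 2 gives 12400 nM. Compound 1 therefore stands highest of the two numbers shown, and compound 2, its nearest neighbour, lies beyond the usual scatter. Compound 3 `Cc1nc(C(NC(=O)C(=O)NC2CCCCCC2)C2CCCCN2)sc1CO` is reported in this assay only as > 90000 nM, which is the limit of > 90000 nM in this assay, at which 1 of the 3 values shown sits, and not a number.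

Compound 4 `Cc1nc(C(NC(=O)C(=O)Nc2ccc(Cl)cc2)C2CCCCN2)sc1CCO` is not yet measured in this assay. It differs from compound 1 by hydrogen in place of methyl on an amine nitrogen in a ring, the same change read one bond further out being 1-methylpiperidin-2-yl to piperidin-2-yl. Among the measured compounds shown here, no pair of measured compounds traces this change alone; compound 2 and compound 3 carry the hydrogen but differ from compound 1 elsewhere as well. The step is expected to be small, within the scatter, with no preferred direction. Compound 4 is estimated at 30000 nM in this assay, between 12000 nM and 90000 nM. The expected step is a 1.2-fold lower number from compound 1 to compound 4 (0.08 log units; within the scatter).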

Compound 4, half-maximal cytotoxic concentration: 32800 nM
Compound 4: middle estimate off by 1.1-fold (0.04 log units), on the low side; the measured number falls inside the stated range.
By their numbers in this assay, from the lowest: compound 2; then compounds 4 and 1 (each within the scatter of the next). At a limit, above all of these: compound 3.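

Hydrogen in place of methyl on an amine nitrogen in a ring can now be read alone: in this assay it gives a 1.1-fold lower number from compound 1 to compound 4 (0.04 log units; within the scatter) and nothing else in the structure differs. Among the compounds shown here, with the rest of the structure held fixed, 1-methylpiperidin-2-yl and piperidin-2-yl cannot be told apart in this read-out, which the earlier compounds could not show, as they carry the hydrogen only together with other differences in ring size, chain length or the group on the oxamide. No measurement shown here accounts for the size of this step.

On these data alone, the reading rests on a single pair, so it remains open whether the same holds where the ring nitrogen bears a larger group, such as ethyl, benzyl or acetyl, or where a carboxylic acid is attached to that nitrogen through a short chain. For the compounds shown here, it also remains open whether the hydrogen and the methyl stay equally matched on a five-membered ring or alongside a shorter hydroxy-bearing chain, since no pair traces the change on those backgrounds.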